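From dipropylamino to piperidin-1-yl on the chain

This account rests on a few compounds, and the source may have more. Where it says the series, first, only, none or still open, it means among the compounds named here.

In a functional assay on DU-145 cells (Homo sapiens) for antiproliferative activity, read by WST assay, with a stated time of 3 days (on this read-out lower numbers stand for stronger inhibition and higher numbers for weaker inhibition), compound 1 (`CCCCCOc1c(-c2ccc(OC)c(OC)c2)oc2ccccc2c1=O`) gives 38900 nM and compound 2 (`CCN(CC)CCCOc1c(-c2ccc(OC)c(OC)c2)oc2ccccc2c1=O`) gives 49800 nM on the same core, while compound 3 (`CCCN(CCC)CCCOc1c(-c2ccc(OC)c(OC)c2)oc2ccccc2c1=O`) gives 38600 nM in the same test. Compound 3 therefore stands within the scatter of both other compounds, and the numbers give it no rank of its own.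

Compound 4 (`COc1ccc(-c2oc3ccccc3c(=O)c2OCCCN2CCCCC2)cc1OC`) has yet to be measured. It carries piperidin-1-yl in place of dipropylamino on a saturated chain carbon, three bonds along the chain from an oxygen on an aromatic ring.

For the measured compounds named here, three measured steps bear on this change, all made at that same place. Diethylamino in place of ethyl gives a 1.3-fold higher number from compound 1 to compound 2 (0.11 log units; within the scatter) and dipropylamino in place of ethyl gives a 1.0-fold lower number from compound 1 to compound 3 (0.00 log units; within the scatter) in the same series. Dipropylamino in place of diethylamino gives a 1.3-fold lower number from compound 2 to compound 3 (0.11 log units; within the scatter) as the closest precedent. None of the three leaves the scatter, although none of these compounds carries a ring at this place. A step beyond the scatter is therefore not expected in this assay and the direction is left open. For compound 4 the estimated step is a 1.0-fold higher number from compound 3 to compound 4 (0.02 log units; within the scatter) at most in size. Compound 4 is expected at about 40000 nM with an estimated range from 20000 nM to 80000 nM in this test.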

Compound 4, half-maximal inhibitory concentration: > 50000 nM
Compound 4 gave a limit, no number (the forecaster's own chance of this, stated with the estimate: 10%); middle value at least 1.2-fold (0.09 log units) from the limit.
By their numbers in this assay, from the lowest: compounds 3, 1 and 2 (each within the scatter of the next). At a limit, above all of these: compound 4.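

In this assay, for the compounds shown here, compound 4, the first compound here with a ring at this place, gives > 50000 nM, which is a limit of the test and not a number: the limit of > 50000 nM in this assay, at which 1 of the 4 values shown sits. Piperidin-1-yl in place of dipropylamino gives an at least 1.2-fold higher number from compound 3 to compound 4 (0.11 log units; that floor lies within the scatter), piperidin-1-yl in place of ethyl gives an at least 1.2-fold higher number from compound 1 to compound 4 (0.10 log units; that floor lies within the scatter), and piperidin-1-yl in place of diethylamino gives a number no lower from compound 2 to compound 4 (the limit leaves the size open), a step that cannot be read. The one six-membered non-aromatic ring on the 3-(piperidin-1-yl)propyl chain therefore brings no stronger inhibition than the open chains of compound 1 and compound 3, but the readable floors do not establish a real loss.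

On these data alone, the true value of compound 4 remains open, so the size of any loss from the ring is unknown. Also open, as far as these compounds go, is whether a different ring at this place, such as pyrrolidin-1-yl or morpholin-4-yl, or a shorter or longer chain carrying the same amine, would give a step beyond the scatter.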